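The compounds below may be only part of what the source reports. "The series", "measured", "known", "first", "only" and "open" are said of these compounds alone.

Of the compounds shown here, three have been measured. Compound 1 `CNC(=O)c1cc(C(=O)N[C@H]2[C@@H]3COC[C@@H]32)c([C@@H](C)c2ccccc2)o1` gives 4.1 in a physicochemical assay for lipophilicity (on this read-out lower numbers stand for lower lipophilicity and higher numbers for higher lipophilicity), the highest of the three numbers. Compound 2 `CC[C@@H](c1ccccc1)n1nc(C(=O)NC)cc1C(=O)N[C@H]1[C@@H]2C[C@H](O)C[C@@H]21` is the nearest to compound 1; in this assay compound 2 gives 3.6, a gap beyond the scatter. Compound 3 `CNC(=O)c1cc(C(=O)NCCO)n([C@@H](C)c2ccccc2)n1` lies furthest away and gives 2.4 in this assay. Compound 4 `CNC(=O)c1cc(C(=O)N[C@H]2[C@@H]3C[C@@H](O)C[C@@H]32)c([C@@H](C)c2ccccc2)o1` has not yet been measured. It differs from compound 1 by a group of 7 heavy atoms (6 carbon, 1 oxygen; one three-membered non-aromatic ring of carbon only, one five-membered non-aromatic ring of carbon only) in place of a group of 6 heavy atoms (5 carbon, 1 oxygen; one three-membered non-aromatic ring of carbon only, one five-membered non-aromatic ring with 1 hetero atom), on an amide-type nitrogen. The entering group carries one hydrogen-bond donor where the leaving group has none. For the measured compounds named here, no step of this kind between measured compounds exists, so the expectation rests on the change alone: compound 4 is expected to fall beyond the scatter, with a step of a number 0.50 log units lower from compound 1 to compound 4 (beyond the scatter). Compound 4 is estimated at 3.6, within 3.1 to 4.1.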

Compound 4, distribution coefficient: 2.8
Estimate against measurement, compound 4: 0.80 log units above; the measured number lies below the stated range.
By their numbers in this assay, from the lowest: compound 3; then compound 4; then compound 2; then compound 1.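

At the amide-type nitrogen, this assay gives the first step read in one place: a number 1.30 log units lower from compound 1 to compound 4 (beyond the scatter), as the group with a five-membered non-aromatic ring of carbon only and a hydrogen-bond donor replaces the group with a five-membered non-aromatic ring with 1 hetero atom and no donor. This position can therefore move the read-out strongly, although the exchange alters the ring and the donor count together. Nothing available explains the size of this step.

The compounds shown leave open whether the ring change or the donor accounts for the step. They also leave open what an amine or a carboxylic acid would do on the same amide-type nitrogen.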